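Bipiperidine in Place of a Fused Bicyclic Amine

The compounds below may be only part of what the source reports. "The series", "measured", "known", "first", "only" and "open" are said of these compounds alone.

Measured compounds:
compound 1 `COc1cc2c(Oc3c(F)cc(NC(=O)NN4C(=O)CSC4c4c(F)cccc4F)cc3F)ccnc2cc1OCCCN1CCC(C)CC1`: 970 nM
compound 2 `COc1cc2c(Oc3c(F)cc(NC(=O)NN4C(=O)CSC4c4c(F)cccc4F)cc3F)ccnc2cc1OCCCN1CCN(C)CC1`: 510 nM
compound 3 `COc1cc2c(Oc3c(F)cc(NC(=O)NN4C(=O)CSC4c4c(F)cccc4F)cc3F)ccnc2cc1OCCCN1C[C@H]2CCCC[C@H]2C1`: 1930 nM

In a functional assay on A549 cells (Homo sapiens) for antiproliferative activity, read by MTT assay, with a stated time of 72 h (a higher number here means a weaker inhibitor, a lower number a stronger inhibitor), compound 3 gives 1930 nM, the highest of the three numbers. The step of a 2.0-fold higher number from compound 1 to compound 3 (0.30 log units; within the scatter) stays within the scatter, whereas the step of a 3.8-fold higher number from compound 2 to compound 3 (0.58 log units; beyond the scatter) lies beyond it, so compound 3 is separated clearly only from compound 2. Compound 4 `COc1cc2c(Oc3c(F)cc(NC(=O)NN4C(=O)CSC4c4c(F)cccc4F)cc3F)ccnc2cc1OCCCN1CCC(N2CCCCC2)CC1` differs from compound 3 in one place: a group of 12 heavy atoms (10 carbon, 2 nitrogen; 2 six-membered non-aromatic rings with 1 hetero atom each) in place of a group of 9 heavy atoms (8 carbon, 1 nitrogen; one five-membered non-aromatic ring with 1 hetero atom, one six-membered non-aromatic ring of carbon only), on a saturated chain carbon, three bonds along the chain from an oxygen on an aromatic ring. For the measured compounds named here, of the measured steps, the one from compound 2 to compound 3 bears most directly on this change, as compound 2 likewise carries a second nitrogen within its amine group; the step of a 1.9-fold lower number from compound 1 to compound 2 (0.28 log units; within the scatter) also touches it but is within the scatter. Going by the values given here, on that basis compound 4 is expected to give a lower number than compound 3, a step of about a 2.8-fold lower number from compound 3 to compound 4 (0.44 log units; beyond the scatter), though no measured pair reproduces this exact group. The estimate for compound 4 in this assay is 700 nM, with a range from 300 nM to 1800 nM.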

Compound 4, half-maximal inhibitory concentration: 380 nM
Compound 4: middle estimate off by 1.8-fold (0.27 log units), on the high side, and the stated range covers the measured number.
By their numbers in this assay, from the lowest: compounds 4, 2, 1 and 3 (each within the scatter of the next, the first and the last beyond it).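

In this assay the bipiperidine, 4-(piperidin-1-yl)piperidin-1-yl, separates clearly from the fused bicyclic amine, with a 5.1-fold lower number from compound 3 to compound 4 (0.71 log units; beyond the scatter) the largest step in this set, so this chain position responds to the shape of the amine as well as to its size. Against 4-methylpiperazin-1-yl the change gives only a 1.3-fold lower number from compound 2 to compound 4 (0.13 log units; within the scatter) and leaves the two unordered, while piperidin-1-yl in place of methyl on a saturated ring carbon gives a 2.6-fold lower number from compound 1 to compound 4 (0.41 log units; beyond the scatter) and so extends the methylpiperidine without loss. The two amines with a second nitrogen, in compound 2 and compound 4, give the lowest numbers, although compound 2 stays within the scatter of compound 1 and so goes against a clean split.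

Nothing available here explains these differences. As far as these compounds go, it remains open whether a morpholine or a dimethylamino group on the same chain carbon would keep the lower numbers.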